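A Fluorine for a Methoxy in a Lipophilicity Series

A few compounds are considered here, and "the series" means these few. Any claim that something is new, unique, unknown or untested is made for them only; others in the source may bear on it.

In a physicochemical assay for lipophilicity, using the shake flask method, in phosphate buffer, measured as octanol-water partition, with a stated time of 85 min, at pH 7.4 (on this read-out higher numbers stand for higher lipophilicity and lower numbers for lower lipophilicity), compound 3 `COc1ccccc1-c1cn2ccnc2c(-c2ccc3ncn(C4CCCCC4)c3c2)n1` gives 1.72, the lowest of the three measured numbers. Compound 1 `c1ccc(-c2cn3ccnc3c(-c3ccc4ncn(C5CCCCC5)c4c3)n2)cc1` gives 1.74, and compound 2 `Cc1cccc(-c2cn3ccnc3c(-c3ccc4ncn(C5CCCCC5)c4c3)n2)c1` gives 1.87; both lie within the scatter of that lowest number, as a number 0.02 log units lower from compound 1 to compound 3 (within the scatter) and a number 0.15 log units lower from compound 2 to compound 3 (within the scatter) show. Compound 4 `Fc1ccccc1-c1cn2ccnc2c(-c2ccc3ncn(C4CCCCC4)c3c2)n1` differs from compound 3 by fluoro in place of methoxy on an aromatic carbon, on an aromatic carbon of a six-membered aromatic ring of carbon only, ortho to a large group. The nearest precedents are small: a number 0.02 log units lower from compound 1 to compound 3 (within the scatter) for methoxy in place of hydrogen and a number 0.13 log units higher from compound 1 to compound 2 (within the scatter) for methyl in place of hydrogen, both within the scatter. A step of similar modest size is therefore expected for compound 4, a number 0.13 log units higher from compound 3 to compound 4 (within the scatter). Compound 4 is expected to give 1.85 in this assay, within a range from 1.55 to 2.15.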

Compound 4, partition coefficient: 1.95
Compound 4: the middle estimate sits 0.10 log units below what was measured; measured number inside the range.
By their numbers in this assay, from the lowest: compounds 3, 1, 2 and 4 (each within the scatter of the next).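

At this position, ortho to a large group, fluoro in place of methoxy keeps the number in this assay within the scatter (a number 0.23 log units higher from compound 3 to compound 4 (within the scatter)), as does fluoro in place of hydrogen (a number 0.21 log units higher from compound 1 to compound 4 (within the scatter)). The swap of 3-methylphenyl for 2-fluorophenyl also stays within it (a number 0.08 log units higher from compound 2 to compound 4 (within the scatter)), so no change among these four compounds has yet separated them on this read-out. No measured evidence accounts for these numbers. From the compounds shown here alone, whether an amine or a carboxylic acid at this position would carry the number beyond the scatter remains open.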